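Bromo for methoxy on the shared core

The source may hold more compounds than are shown below. What is called first, only, known or untested is meant among the compounds shown, and "the series" means these compounds.

Measured compounds:
compound 1 `COc1cc(Cl)cc2nc(N3CCN(C)CC3)oc12` gives 6.16 in a functional assay on ileum (strain Hartley) for agonist activity at 5-hydroxytryptamine receptor 3A (Cavia porcellus); on this read-out higher numbers stand for higher potency (the scale is a negative logarithm) and lower numbers for lower potency
compound 2 `COc1ccc2oc(N3CCN(C)CC3)nc2c1` gives 4.78 in this assay
compound 3 `CCc1cc(Cl)cc2nc(N3CCN(C)CC3)oc12` gives 6.82 in this assay

Among the three measured compounds, compound 2 stands lowest in this assay, well below both compound 1 and compound 3, and each of those gaps lies beyond the scatter.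

Compound 4 `CN1CCN(c2nc3cc(Br)ccc3o2)CC1` is not yet measured. It differs from compound 2 in one place: bromo in place of methoxy on an aromatic carbon. The change sits on an aromatic carbon of a six-membered aromatic ring of carbon only, part of a fused system of two rings; meta to a fused ring; para to a fused ring.

Within the data shown here, only one measured step bears on this. Going from compound 1 to compound 3, ethyl replaces methoxy on an aromatic carbon, and the step is a number 0.66 log units higher from compound 1 to compound 3 (beyond the scatter). That step removes a methoxy and puts in a group without a hydrogen-bond acceptor, as the change to compound 4 does, though the entering group differs and the core of compound 2 carries no chlorine. On that slim basis a modest rise in this assay is expected.

Compound 4 is therefore estimated at 5.5 in this assay, within 4.8 to 6.3, which is expected to amount to a number 0.72 log units higher from compound 2 to compound 4 (beyond the scatter).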

Compound 4, negative logarithm of the half-maximal effective concentration: 6.21
For compound 4 the middle estimate is 0.71 log units below the measured one; measured number inside the range.
By their numbers in this assay, from the lowest: compound 2; then compounds 1 and 4 (each within the scatter of the next); then compound 3.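

In this assay, bromo in place of methoxy on this aromatic carbon gives a number 1.43 log units higher from compound 2 to compound 4 (beyond the scatter), so the number at this position of the core of compound 2 responds strongly to the change. Among these compounds, the only earlier step that removes a methoxy, a number 0.66 log units higher from compound 1 to compound 3 (beyond the scatter), has ethyl entering on a core that carries chlorine; the new step shows a rise in the same direction with a halogen entering, on a core with no chlorine. The data shown offer no measurement that accounts for this rise.

It remains open whether the gain belongs to bromo itself or would also appear with chloro, methyl or an amine on this aromatic carbon, as bromo is the only replacement for methoxy shown on this core. Also unresolved is how much of the step comes from losing the methoxy and how much from gaining the bromo, a question that the same core with plain hydrogen on this carbon could help to separate.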